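A few compounds are considered here, and "the series" means these few. Any claim that something is new, unique, unknown or untested is made for them only; others in the source may bear on it.

The measured compounds are these:

Compound 1 `O=S(=O)(c1ccc2cccnc2c1)n1cc(C2=CCNCC2)c2ccccc21` gives 7 nM in an assay on HEK293 cells for displacement of a labelled ligand from 5-hydroxytryptamine receptor 6 (Homo sapiens), read by scintillation counting; a lower number here means a stronger inhibitor, a higher number a weaker inhibitor.
Compound 2 `O=S(=O)(c1cc2ccccc2cn1)n1cc(C2=CCNCC2)c2ccccc21` gives 12 nM in this assay.
Compound 3 `Cc1c(C2=CCNCC2)c2ccccc2n1S(=O)(=O)c1ccc2cccnc2c1` gives 18 nM in this assay.

Compound 1 and compound 3 share a core and differ in one place, by methyl in place of hydrogen on an aromatic carbon. That change made a step of a 2.6-fold higher number from compound 1 to compound 3 (0.41 log units; beyond the scatter), a modest weakening that nonetheless lies beyond the scatter of repeated measurements.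

Compound 2 is built from the same atoms as compound 1, joined differently; the difference between the two cores is not broken down here. Their two values lie within the scatter of each other, so nothing can be said about an order between them, and the same holds for compound 2 against compound 3.

Compound 4 `Cc1c(C2=CCNCC2)c2ccccc2n1S(=O)(=O)c1cc2ccccc2cn1` has not yet been measured. It stands to compound 2 as compound 3 stands to compound 1: the difference is methyl in place of hydrogen on an aromatic carbon, and the surroundings of the place are described in the same words for both pairs, so this is the same change made on the core of compound 2. Going by the values given here, with only one measured instance of the change, the expectation for compound 4 in this assay rests on compound 1 and compound 3 alone, whose step was a 2.6-fold higher number from compound 1 to compound 3 (0.41 log units; beyond the scatter). On that basis the step from compound 2 is expected to be a 2.5-fold higher number from compound 2 to compound 4 (0.40 log units; beyond the scatter). Compound 4 is therefore estimated at 30 nM, with a likely range from 12 nM to 75 nM.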

Compound 4, inhibition constant: 20 nM
The estimate for compound 4 lay 1.5-fold (0.18 log units) above the measured number; low and high end bracket the measured number.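

In this assay, methyl in place of hydrogen on an aromatic carbon gave a 1.7-fold higher number from compound 2 to compound 4 (0.22 log units; within the scatter), so on the core of compound 2 the change separates the two compounds by no more than repeated measurements would, whereas on the core of compound 1 it gave a 2.6-fold higher number from compound 1 to compound 3 (0.41 log units; beyond the scatter), a modest step beyond the scatter. Set side by side, the two steps cannot be told apart: the same change on two cores in this assay, a 2.6-fold higher number (0.41 log units; beyond the scatter) from compound 1 to compound 3 and a 1.7-fold higher number (0.22 log units; within the scatter) from compound 2 to compound 4, 1.5-fold (0.19 log units) apart, within the scatter of two such steps. Going by these compounds alone, the two pairs are therefore compatible with one step of similar size carried from one core to the other, but they do not show that the size is the same on both, and with only two pairs they establish no rule for the series.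

The compounds shown hold only hydrogen or methyl at this place, so it remains open what an ethyl group, a longer chain, a chlorine atom or a hydroxymethyl group would do there. It is also open whether the step would carry over to compounds with an amide in place of the sulfonyl link, since all four compounds shown share that link.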